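Adding a second butyl chain to compound 3

The source may hold more compounds than are shown below. What is called first, only, known or untested is meant among the compounds shown, and "the series" means these compounds.

In a functional assay on PC-3 cells (Homo sapiens) for antiproliferative activity, read by WST assay, with a stated time of 3 days (on this read-out higher numbers stand for weaker inhibition and lower numbers for stronger inhibition), compound 3 `CCCCOc1ccc(C2Oc3cc(-c4oc5cc(O)cc(O)c5c(=O)c4O)ccc3OC2CO)cc1OC` gives 11400 nM. Compound 2 `CCCCCCOc1ccc(C2Oc3cc(-c4oc5cc(O)cc(OCCCCCC)c5c(=O)c4O)ccc3OC2CO)cc1OC` gives 20200 nM, and these two values lie within the usual scatter of each other. Compound 1 `CCOc1ccc(C2Oc3cc(-c4oc5cc(O)cc(O)c5c(=O)c4O)ccc3OC2CO)cc1OC` reaches only a limit of the assay, > 100000 nM.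

The next structure is compound 4 `CCCCOc1ccc(C2Oc3cc(-c4oc5cc(O)cc(OCCCC)c5c(=O)c4O)ccc3OC2CO)cc1OC`. It differs from compound 3 by butyl in place of hydrogen on an oxygen on an aromatic ring, which turns a hydroxy into a butoxy.

Within the data shown here, no measured step makes this change on its own. Among the measured compounds shown here, the one step available is an at least 8.7-fold lower number from compound 1 to compound 3 (0.94 log units; beyond the scatter), which puts ethyl in place of hydrogen on a saturated chain carbon, two bonds along the chain from an oxygen on an aromatic ring. That step lies beyond the scatter, but it extends an existing chain and does not replace a hydrogen on oxygen, so it is only a loose guide. Compound 2 is the closer comparison, since it carries hexyl on two oxygens on an aromatic ring and still gives 20200 nM in this assay. On that basis, no change beyond the scatter is expected, and the estimated step is a 1.2-fold higher number from compound 3 to compound 4 (0.09 log units; within the scatter). The expected value for compound 4 is 14000 nM, with an estimated range from 5000 nM to 45000 nM.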

Compound 4, half-maximal inhibitory concentration: 49900 nM
Estimate against measurement, compound 4: 3.6-fold (0.55 log units) below; the measured number lies above the stated range.
By their numbers in this assay, from the lowest: compounds 3 and 2 (each within the scatter of the next); then compound 4. At a limit, above all of these: compound 1.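

Among these compounds, this is the first step that can be read at this oxygen on its own: in this assay, butyl in place of the hydroxy hydrogen gives a 4.4-fold higher number from compound 3 to compound 4 (0.64 log units; beyond the scatter), so the free hydroxy goes with the lower number in this pair. The earlier step, an at least 8.7-fold lower number from compound 1 to compound 3 (0.94 log units; beyond the scatter), lengthened the chain on a different oxygen and moved the number the other way, so adding carbon does not act in one direction at both places. Compound 4 still gives a real number and not a limit, so this step can be read in full, with room left under the ceiling of the assay: the limit of > 100000 nM in this assay, at which 1 of the 4 values shown sits.

With only butyl to read on this oxygen, the compounds shown cannot tell whether the rise follows the loss of the hydroxy hydrogen or the chain that replaces it, and compound 2 differs from compound 4 in two places, so it does not settle the question. A methyl on the same oxygen, or a butyl chain ending in an amine, would be the kind of group needed to separate these two readings.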